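The source may hold more compounds than are shown below. What is called first, only, known or untested is meant among the compounds shown, and "the series" means these compounds.

Compounds measured so far in a functional assay on the whole organism (strain Wistar) for inhibition, with Rattus norvegicus as the target, read by paw edema, with stated times of 30 min and 3 h, at a dose of 20 mg/kg; on this read-out higher numbers stand for more inhibition at the one dose given (going by the name of the read-out) and lower numbers for less inhibition:
compound 1 `CCOC(=O)C1=C(C)NC(C)=C(C(=O)OCC)C1c1ccc(OCC(=O)Nc2c(C)cccc2C)cc1` gives 53.9%
compound 2 `CCOC(=O)C1=C(C)NC(C)=C(C(=O)OCC)C1c1ccc(OCC(=O)Nc2ccc(C)cc2)cc1` gives 61.1%
compound 3 `CCOC(=O)C1=C(C)NC(C)=C(C(=O)OCC)C1c1ccc(OCC(=O)NNC(=O)c2ccc(C)cc2)cc1` gives 47.3%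

Compound 3 has the lowest of the three numbers: it sits within the scatter of compound 1 a number 6.6 percentage points lower from compound 1 to compound 3 (within the scatter) but beyond it against compound 2 a number 13.8 percentage points lower from compound 2 to compound 3 (beyond the scatter). Compound 4 `CCOC(=O)C1=C(C)NC(C)=C(C(=O)OCC)C1c1ccc(OCC(=O)NNC(=O)CCC(=O)O)cc1` differs from compound 3 in one place: 2-carboxyethyl in place of 4-methylphenyl on a carbonyl carbon. Within the data shown here, no measured step alters the group on this carbonyl carbon; the three known steps all vary the group on the amide-type nitrogen, and the only step beyond the scatter, a number 13.8 percentage points lower from compound 2 to compound 3 (beyond the scatter), was modest. The reference frame therefore gives little ground for a large shift. Compound 4 is expected to stay near compound 3, with a small downward step a number 5.3 percentage points lower from compound 3 to compound 4 (within the scatter), estimated at 42% within 30% to 55%.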

Compound 4, a percentage reported as inhibition, in the whole organism at one dose (the size of the read-out at that dose, not a potency): 56.9%
Compound 4: middle estimate off by 14.9 percentage points, on the low side, outside the stated range (above it).
By their numbers in this assay, from the lowest: compounds 3, 1, 4 and 2 (each within the scatter of the next, the first and the last beyond it).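

In this assay, 2-carboxyethyl in place of 4-methylphenyl on the carbonyl carbon gives a number 9.6 percentage points higher from compound 3 to compound 4 (within the scatter), so at this position the ring can give way to an open chain with no step beyond the scatter. The ((2-carboxyethyl)carbonyl)amino group also stays level with both aryl groups on the amide-type nitrogen, with a number 4.2 percentage points lower from compound 2 to compound 4 (within the scatter) and a number 3 percentage points higher from compound 1 to compound 4 (within the scatter). No evidence is available to explain this result. Still open, as far as these compounds go, is whether the free carboxylic acid matters here, or whether its ethyl ester, a longer chain or a terminal amine would read the same.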